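The source may report more compounds than this note shows. Statements on the series, on what has been measured and on what is new or still open speak of the compounds shown alone.

Compounds 1, 2 and 3 share one core and differ only in the chain on an aromatic carbon: compound 1 `CC(C)c1ccc(NC(=O)N[C@@H](C)c2ccccc2)cc1`, compound 2 `CCCc1ccc(NC(=O)N[C@@H](C)c2ccccc2)cc1` and compound 3 `CCCCCc1ccc(NC(=O)N[C@@H](C)c2ccccc2)cc1`. In an ADME assay on the whole organism with Oryza sativa as the target, tested at 0.1 uM (on this read-out lower numbers stand for a stronger effect and higher numbers for a weaker effect at the one concentration tested), compound 1 gives 98%, compound 2 gives 97% and compound 3 gives 98%, so compound 3 stands level with compound 1 and within the usual scatter of compound 2: a number 1 percentage points lower from compound 1 to compound 2 (within the scatter), no change at the digits printed from compound 1 to compound 3 (within the scatter) and a number 1 percentage points higher from compound 2 to compound 3 (within the scatter). Compound 4 `CCCCCCCc1ccc(NC(=O)N[C@@H](C)c2ccccc2)cc1` differs from compound 3 in one place: ethyl in place of hydrogen on a saturated chain carbon, five bonds along the chain from an aromatic carbon. The closest guide is a number 1 percentage points higher from compound 2 to compound 3 (within the scatter), the same kind of lengthening, which stayed within the scatter. The expected step is therefore a number 1 percentage points lower from compound 3 to compound 4 (within the scatter), nothing beyond the scatter in this assay. Compound 4 is estimated at 97%, with a range from 91% to 100%.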

Compound 4, a percentage reported as activity, at one concentration (the size of the read-out at that concentration, not a potency): 100%
Compound 4: middle estimate off by 3 percentage points, on the low side; measured number inside the range.
By their numbers in this assay, from the lowest: compounds 2, 1, 3 and 4 (each within the scatter of the next).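

Lengthening the chain to heptyl in this assay gives a number 2 percentage points higher from compound 3 to compound 4 (within the scatter), a number 3 percentage points higher from compound 2 to compound 4 (within the scatter) and a number 2 percentage points higher from compound 1 to compound 4 (within the scatter). The longest chain shown therefore still produces no step beyond the scatter, so isopropyl, propyl, pentyl and heptyl on this aromatic carbon cannot be told apart in this read-out. No evidence is available to explain this result. The compounds shown leave open whether a chain longer than heptyl would behave the same way. They also leave open what an amine or a carboxylic acid at the end of the chain would do.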